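Exchanging one group on the nitrogen of compound 3

The source may hold more compounds than are shown below. What is called first, only, known or untested is meant among the compounds shown, and "the series" means these compounds.

In a functional assay on HL-60 cells (Homo sapiens) for cytotoxicity, read by MTT assay, with a stated time of 3 days (a lower number here means a stronger inhibitor, a higher number a weaker inhibitor), compound 3 (`N#Cc1c(NC(N)=S)nc(SCc2nc3ccccc3[nH]2)nc1-c1ccccc1`) gives 5.81 nM. Compound 1 (`CNc1nc(SCc2nc3ccccc3[nH]2)nc(-c2ccccc2)c1C#N`) gives 6.57 nM, within the scatter of that number, and compound 2 (`N#Cc1c(Nc2nccs2)nc(SCc2nc3ccccc3[nH]2)nc1-c1ccccc1`) gives 11.9 nM. Compound 4 (`N#Cc1c(NC(N)=O)nc(SCc2nc3ccccc3[nH]2)nc1-c1ccccc1`) differs from compound 3 by a group of 3 heavy atoms (1 carbon, 1 nitrogen, 1 oxygen; no ring) in place of a group of 3 heavy atoms (1 carbon, 1 nitrogen, 1 sulfur; no ring), on a nitrogen on an aromatic ring: carbamoyl enters on a nitrogen on an aromatic ring. For the measured compounds named here, no measured step exchanges sulfur for oxygen. The nearest evidence comes from changes on the same nitrogen: a 1.8-fold higher number from compound 1 to compound 2 (0.26 log units; within the scatter), a 1.1-fold lower number from compound 1 to compound 3 (0.05 log units; within the scatter) and the modest 2.0-fold lower number from compound 2 to compound 3 (0.31 log units; beyond the scatter). All three steps are small, so no change beyond the scatter is expected in this assay, and no direction is favoured. The expected step is a 1.2-fold higher number from compound 3 to compound 4 (0.08 log units; within the scatter). For compound 4 the estimated value is 7 nM, with an expected range of 3 nM to 16 nM.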

Compound 4, half-maximal inhibitory concentration: 2.9 nM
Beside the measured number, compound 4's estimate is 2.4-fold (0.38 log units) above it; measured number below the stated range.
By their numbers in this assay, from the lowest: compounds 4, 3, 1 and 2 (each within the scatter of the next, the first and the last beyond it).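

In this assay, for the compounds shown here, carbamoyl is the only group on this nitrogen that stands clear of both methyl (a 2.3-fold lower number from compound 1 to compound 4 (0.36 log units; beyond the scatter)) and 1,3-thiazol-2-yl (a 4.1-fold lower number from compound 2 to compound 4 (0.61 log units; beyond the scatter)). The group from compound 3 does so only against 1,3-thiazol-2-yl, yet the exchange of its sulfur for oxygen (a 2.0-fold lower number from compound 3 to compound 4 (0.30 log units; within the scatter)) does not separate the two groups. Nothing available explains these steps.

Open, on these data alone, is whether an unsubstituted amine or an acetyl group on the same nitrogen would match carbamoyl in this assay. Also open, as far as these compounds go, is whether a longer chain on the terminal nitrogen of carbamoyl would be tolerated.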